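The compounds below may be only part of what the source reports. "The series", "measured", "known", "first", "only" and "open" are said of these compounds alone.

Measured in a functional assay on MCF7 cells (Homo sapiens) for antiproliferative activity, read by CCK-8 assay, with a stated time of 48 h; a lower number here means a stronger inhibitor, a higher number a weaker inhibitor:
Compound 1 `C=C(C)C(=O)NCCOc1ccc(Oc2c(-c3ccc(F)cc3)sc3cc(O)ccc23)cc1`: > 25000 nM (a limit)
Compound 2 `O=C(/C=C/CN1CC(Oc2ccc(Oc3c(-c4ccc(F)cc4)sc4cc(O)ccc34)cc2)C1)N1CCC1`: > 25000 nM (a limit)
Compound 3 `O=C(/C=C/CNCCOc1ccc(Oc2c(-c3ccc(F)cc3)sc3cc(O)ccc23)cc1)N1CCC1`: 7340 nM

For the measured compounds named here, compound 3, at 7340 nM, is the only compound here with an actual number. The other two compounds stand at the limit of > 25000 nM in this assay, at which 2 of the 3 values shown sit.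

Compound 4 `CN(C)C(=O)/C=C/CN1CC(Oc2ccc(Oc3c(-c4ccc(F)cc4)sc4cc(O)ccc34)cc2)C1` has the same atoms as compound 3, joined differently: 1-(3-(dimethylcarbamoyl)prop-2-en-1-yl)azetidin-3-yl in place of 2-((3-((azetidin-1-yl)carbonyl)prop-2-en-1-yl)amino)ethyl on an oxygen on an aromatic ring. Going by the values given here, the only measured step, an at least 3.4-fold lower number from compound 1 to compound 3 (0.53 log units; beyond the scatter), lies at an amine nitrogen rather than at this oxygen, so it offers only a rough guide to size. Among the compounds with values here, with compound 3 the sole compound measured below the limit, a move towards weaker inhibition is expected, of modest size. The expected change is a 2.5-fold higher number from compound 3 to compound 4 (0.39 log units; beyond the scatter). Compound 4 is estimated at 18000 nM, with an expected range of 7000 nM to 40000 nM.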

Compound 4, half-maximal inhibitory concentration: 22300 nM
For compound 4 the middle estimate is 1.2-fold (0.09 log units) below the measured one; the measured number falls inside the stated range.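

In this assay, at the oxygen on an aromatic ring, joining the same atoms differently is not neutral: 1-(3-(dimethylcarbamoyl)prop-2-en-1-yl)azetidin-3-yl in place of 2-((3-((azetidin-1-yl)carbonyl)prop-2-en-1-yl)amino)ethyl gives a 3.0-fold higher number from compound 3 to compound 4 (0.48 log units; beyond the scatter). This step also removes the one hydrogen-bond donor of the group, and it gives a second measured number in this series. Dimethylamino in place of azetidin-1-yl on a carbonyl carbon gives an at least 1.1-fold lower number from compound 2 to compound 4 (0.04 log units; that floor lies within the scatter). 1-(3-(dimethylcarbamoyl)prop-2-en-1-yl)azetidin-3-yl in place of 2-(((1-methylethenyl)carbonyl)amino)ethyl on an oxygen on an aromatic ring gives an at least 1.1-fold lower number from compound 1 to compound 4 (0.04 log units; that floor lies within the scatter). Neither of these two steps can be read further, because each starts from a limit: the limit of > 25000 nM in this assay, at which 2 of the 4 values shown sit.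

The compounds shown do not separate the effect of the azetidine from that of the amide. As far as these compounds go, how a longer chain or a piperidine at this oxygen would compare remains open.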